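This account rests on a few compounds, and the source may have more. Where it says the series, first, only, none or still open, it means among the compounds named here.

Compound 1 `CCn1c(C(=O)NCCCN(C)C)ccc1C(CC)(CC)c1ccc(OCCC(O)(CC)CC)c(C)c1` gives 5 nM in an assay on cells for agonist activity at vitamin D3 receptor (Homo sapiens), with a stated time of 96 h; a higher number here means that more compound is needed for the effect, a lower number that less compound is needed.
Compound 2 `CCn1c(C(=O)NCCN)ccc1C(CC)(CC)c1ccc(OCCC(O)(CC)CC)c(C)c1` gives 156 nM in this assay.
Compound 3 `CCOC(=O)C(CC(=O)OC)NC(=O)c1ccc(C(CC)(CC)c2ccc(OCCC(O)(CC)CC)c(C)c2)n1CC` gives 21 nM in this assay.

Among these three, compound 1 has the lowest number in this assay, so it needs the least compound for the effect. The nearest to it is compound 3, reached by the step of a 4.2-fold higher number from compound 1 to compound 3 (0.62 log units; beyond the scatter); the furthest is compound 2, reached by the step of a 31-fold higher number from compound 1 to compound 2 (1.49 log units; beyond the scatter).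

Compound 4 `CCn1c(C(=O)N(C)CCO)ccc1C(CC)(CC)c1ccc(OCCC(O)(CC)CC)c(C)c1` has not been measured. It differs from compound 1 in a single place: (2-hydroxyethyl)(methyl)amino in place of (3-(dimethylamino)propyl)amino on a carbonyl carbon. Both measured steps from compound 1 also change the group attached to the amide, and both raised the number: the exchange of the (dimethylamino)methyl for amino in a 31-fold higher number from compound 1 to compound 2 (1.49 log units; beyond the scatter) was large, while the replacement with the larger group of 11 heavy atoms in a 4.2-fold higher number from compound 1 to compound 3 (0.62 log units; beyond the scatter) was modest. Since compound 4 likewise loses the (3-(dimethylamino)propyl)amino group, a higher number than compound 1 is expected, most likely of modest size, as the step of a 6.0-fold higher number from compound 1 to compound 4 (0.78 log units; beyond the scatter) expresses. Compound 4 is therefore estimated at 30 nM, within a range from 8 nM to 120 nM.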

Compound 4, half-maximal effective concentration: 52.7 nM
Estimate against measurement, compound 4: 1.8-fold (0.24 log units) below, within the range that was stated.
By their numbers in this assay, from the lowest: compound 1; then compound 3; then compound 4; then compound 2.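

In this assay, the change on this carbonyl carbon gives an 11-fold higher number from compound 1 to compound 4 (1.02 log units; beyond the scatter), a large loss even though the leaving and entering groups have equal counts of hydrogen-bond donors and acceptors, so those counts alone do not set the number here. The entering (2-hydroxyethyl)(methyl)amino group also gives a 2.5-fold higher number from compound 3 to compound 4 (0.40 log units; beyond the scatter) and a 3.0-fold lower number from compound 2 to compound 4 (0.47 log units; beyond the scatter), so all three replacements of the (3-(dimethylamino)propyl)amino group raise the number, by clearly different amounts. Nothing available explains these steps.

Compound 4 differs from compound 1 both in its chain and in the methyl on its nitrogen, and the compounds shown cannot separate these two changes. A (3-hydroxypropyl)amino group or a (2-(dimethylamino)ethyl)amino group on the same carbonyl carbon would help to tell them apart.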